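Chalcone-type enone swap on the fused core

The compounds below may be only part of what the source reports. "The series", "measured", "known", "first", "only" and "open" are said of these compounds alone.

Within the data shown here, compound 3 `COc1cc(-c2cc(C(=O)/C=C/c3ccc(Cl)cc3)nc3cc(-c4ccccc4)nn23)cc(OC)c1OC` stands lowest of the three numbers so far in an ADME assay on HEK293 cells (Homo sapiens) for antiproliferative activity, read by MTT assay, with a stated time of 24 h (a lower number here means a stronger inhibitor, a higher number a weaker inhibitor), where compound 3 gives 53900 nM, although its gaps to the other two are within the scatter. Among the measured compounds shown here, compound 2 `COc1ccc(-c2cc(/C=C/C(=O)c3ccc(C)cc3)nc3cc(-c4ccccc4)nn23)cc1OC` gives 62600 nM and compound 1 `COc1cc(-c2cc(/C=C/C(=O)c3ccc(C)c(C)c3)nc3cc(-c4ccccc4)nn23)cc(OC)c1OC` gives 72500 nM; the only measured single-point step is a 1.3-fold lower number from compound 1 to compound 3 (0.13 log units; within the scatter), which did not move the number beyond the scatter.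

Compound 4 `COc1cc(-c2cc(/C=C/C(=O)c3ccc(C)cc3)nc3cc(-c4ccccc4)nn23)cc(OC)c1OC` is the next member: 2-((4-methylphenyl)carbonyl)ethenyl in place of (2-(4-chlorophenyl)ethenyl)carbonyl on an aromatic carbon. This change reverses the sense of the carbonyl-ethenyl linker and returns to the type of enone seen in compounds 1 and 2. The step from compound 1 to compound 3 is the one that bears on it, and it was small; compound 2, which carries the same enone as compound 4 on a dimethoxy rather than trimethoxy ring, sits close to compound 3 as well. Nothing in the series therefore suggests that this swap should shift this assay beyond the scatter, so the step is expected to be a 1.3-fold higher number from compound 3 to compound 4 (0.10 log units; within the scatter).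

Compound 4 is estimated at 68000 nM in this assay, with a range of 40000 nM to 115000 nM.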

Compound 4, half-maximal inhibitory concentration: 50400 nM
Estimate against measurement, compound 4: 1.3-fold (0.13 log units) above; the range from low to high includes it.
By their numbers in this assay, from the lowest: compounds 4, 3, 2 and 1 (each within the scatter of the next).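

In this assay, placing 2-((4-methylphenyl)carbonyl)ethenyl in place of (2-(4-chlorophenyl)ethenyl)carbonyl on this aromatic carbon gives a 1.1-fold lower number from compound 3 to compound 4 (0.03 log units; within the scatter), so this exchange, which turns the linker around and replaces the ring chlorine with a ring methyl, does not separate the two compounds. With compound 4 in hand, two smaller edits on the same enone type can also be read: methoxy in place of hydrogen on an aromatic carbon gives a 1.2-fold lower number from compound 2 to compound 4 (0.09 log units; within the scatter), and hydrogen in place of methyl on an aromatic carbon gives a 1.4-fold lower number from compound 1 to compound 4 (0.16 log units; within the scatter), so neither edit moves the number beyond the scatter. Nothing available accounts for this flat behaviour.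

Because the step from compound 3 to compound 4 alters both the linker sense and the ring substituent, the compounds shown leave open what each change does alone, and whether the two effects could be offsetting. Also open, from the compounds shown here alone, is whether a more different group at the end of the enone, such as an amine or a carboxylic acid on the phenyl ring, would move the number beyond the scatter.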